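A few compounds are considered here, and "the series" means these few. Any claim that something is new, unique, unknown or untested is made for them only; others in the source may bear on it.

Compound 1 `Nc1nc(NC2CC2)c2ncn(/C=C3/CC3(CO)CO)c2n1`: > 20000 nM
Compound 2 `CCCNc1nc(N)nc2c1ncn2/C=C1/CC1(CO)CO`: "not determined" (no result reported)

In an ADME assay on MOLT-3 cells (Homo sapiens) for cytotoxicity, with a stated time of 7 days (on this read-out higher numbers stand for lower toxicity in this test and lower numbers for higher toxicity in this test), compound 1 gives > 20000 nM, which is a limit of the assay and not a number. Compound 2 has no single number in this assay, and its entry reads "not determined" (no result reported). For the measured compounds named here, the only value to set it against is the limit of > 20000 nM in this assay, at which 1 of the 2 values shown sits.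

Compound 3 `CCCCCCSc1nc(N)nc2c1ncn2/C=C1/CC1(CO)CO` carries hexylsulfanyl in place of propylamino on an aromatic carbon. Going by the values given here, no measured step bears on this change, so only a modest move toward lower numbers in this assay is expected, somewhat beyond the scatter. Compound 3 is estimated at 10000 nM, with an expected range of 2500 nM to 25000 nM.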

Compound 3, half-maximal cytotoxic concentration: > 20000 nM
Compound 3: no number, only a limit; the forecaster's own chance of this, stated with the estimate: 45%; at least 2.0-fold (0.30 log units) between middle value and limit.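

For the compounds shown here, compound 1 and compound 3 both stand at limits and not at numbers, and no step between them can be read. The compounds shown leave open whether changing the group on this aromatic carbon shifts the read-out at all.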